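Ethoxy to benzyloxy in a series at the limit

The source may report more compounds than this note shows. Statements on the series, on what has been measured and on what is new or still open speak of the compounds shown alone.

In an ADME assay on MOLT-3 cells (Homo sapiens) for cytotoxicity, with a stated time of 7 days (a lower number here means that less compound is tolerated, a higher number that more compound is tolerated), compound 1 `CNc1nc(N)nc2c1ncn2/C=C1/CC1(CO)CO` gives > 20000 nM, which is a limit. Compound 2 `Nc1nc(OCC(F)(F)F)c2ncn(/C=C3/CC3(CO)CO)c2n1` gives > 20000 nM, also a limit. Compound 3 `CCOc1nc(N)nc2c1ncn2/C=C1/CC1(CO)CO` gives > 20000 nM, again a limit and not a number. Among the compounds with values here, the series so far therefore rests at the limit of > 20000 nM in this assay, at which 3 of the 3 values shown sit.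

Compound 4 `Nc1nc(OCc2ccccc2)c2ncn(/C=C3/CC3(CO)CO)c2n1` takes ethoxy to benzyloxy: phenyl in place of methyl on a saturated chain carbon bound to an oxygen on an aromatic ring.

The closest evidence is a step that the two limits leave unreadable from compound 2 to compound 3, at the same place. Two further comparisons are a step that the two limits leave unreadable from compound 1 to compound 3 and a step that the two limits leave unreadable from compound 1 to compound 2. None of these gives a size, so no step beyond the scatter can be forecast in either direction, although a readable value remains possible.

The expected change is a number no higher from compound 3 to compound 4 (the limit leaves the size open).

The estimate for compound 4 is 20000 nM, with an expected range of 8000 nM to 25000 nM.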

Compound 4, half-maximal cytotoxic concentration: > 20000 nM
Compound 4 gave a limit, no number; the forecaster's own chance of this, stated with the estimate: 75%; the middle value sits exactly at the limit.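

Compound 4 gives > 20000 nM in this assay, again a limit, so the steps from compound 1, compound 2 and compound 3 to compound 4 cannot be read: the limit of > 20000 nM in this assay, at which 4 of the 4 values shown sit.

The compounds shown leave open whether any change at this place gives a readable number in this assay.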